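Methoxy Position Swap on the Benzamide Arm

The source may report more compounds than this note shows. Statements on the series, on what has been measured and on what is new or still open speak of the compounds shown alone.

Measured compounds in an assay on MDA-MB-231 cells for binding affinity to C-X-C chemokine receptor type 4 (Homo sapiens), read by immunofluorescence and microscopy, with stated times of 10 min and 30 min; on this read-out lower numbers stand for an effect already at smaller amounts and higher numbers for an effect only at larger amounts of compound:
compound 1, `COc1ccc(C(=O)NCc2ccc(CNS(=O)(=O)c3ccc(C)cc3)cc2)cc1`: 100 nM
compound 2, `Cc1ccc(S(=O)(=O)NCc2ccc(CNC(=O)c3c(Cl)cc(Cl)cc3Cl)cc2)cc1`: 10 nM
compound 3, `Cc1ccc(S(=O)(=O)NCc2ccc(CNC(=O)c3ccccc3F)cc2)cc1`: 1000 nM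

Compound 3 stands at the highest of the three numbers; its nearest neighbour is compound 1 and its furthest is compound 2. The steps spell this out: a 10-fold higher number from compound 1 to compound 3 (1.00 log units; beyond the scatter), and a 100-fold higher number from compound 2 to compound 3 (2.00 log units; beyond the scatter). The remaining step, a 10-fold lower number from compound 1 to compound 2 (1.00 log units; beyond the scatter), sets compound 2 apart from the other two.

Compound 4, `COc1cccc(C(=O)NCc2ccc(CNS(=O)(=O)c3ccc(C)cc3)cc2)c1`, differs from compound 3 in one place, on the carbonyl carbon: 3-methoxyphenyl in place of 2-fluorophenyl on a carbonyl carbon. Among the compounds with values here, no measured pair exchanges a fluorine-bearing ring for a 3-methoxyphenyl group, so the precedent is indirect. The step that bears most on it is a 10-fold higher number from compound 1 to compound 3 (1.00 log units; beyond the scatter), since compound 1 carries a methoxyphenyl group on that same carbonyl carbon and gives 100 nM. Because compound 1 gives 100 nM, the number for compound 4 is expected to fall nearer to it than to the fluorinated compound, and the step expected for compound 4 is a 5.0-fold lower number from compound 3 to compound 4 (0.70 log units; beyond the scatter). The estimate for compound 4 in this assay is 200 nM, with a range from 50 nM to 1000 nM.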

Compound 4, effective concentration (reported as EC, without a stated level of effect): 10 nM
Beside the measured number, compound 4's estimate is 20-fold (1.30 log units) above it; the measured number lies below the stated range.
By their numbers in this assay, from the lowest: compounds 2 and 4 (each within the scatter of the next); then compound 1; then compound 3.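

In this assay, moving from the 4-methoxyphenyl to the 3-methoxyphenyl group on the carbonyl carbon is not a neutral swap: the result is a 10-fold lower number from compound 1 to compound 4 (1.00 log units; beyond the scatter) and is beyond the scatter, so compound 1 could not stand for every methoxyphenyl group at this place. The 3-methoxyphenyl group also matches the 2,4,6-trichlorophenyl group, with no change at the digits printed from compound 2 to compound 4 (within the scatter) and the two lying within the scatter, which shows that the low number seen earlier only with three chlorine atoms on the ring is also reached by a ring with no chlorine at all. Against the 2-fluorophenyl group the same place gives a 100-fold lower number from compound 3 to compound 4 (2.00 log units; beyond the scatter) and so spans the whole spread of numbers seen in this small set, making the identity of the ring substituent on the carbonyl carbon decisive here.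

Nothing available explains why these groups differ as they do. From the compounds shown here alone, it remains open whether the effect belongs to the methoxy group itself or to any substituent placed as in the 3-methoxyphenyl group, as a hydroxyl, an amine or a carboxylic acid in place of the methoxy group would show.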